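Moving the Pyridine Nitrogen: Cytotoxicity Outlook for Compound 4

The source may hold more compounds than are shown below. What is called first, only, known or untested is meant among the compounds shown, and "the series" means these compounds.

Measured so far:
Compound 1, `Cc1cc(C)cc(Cn2c(=O)cc(N=[N+]=[N-])n(Cc3ccccn3)c2=O)c1`: in an ADME assay on MT4 cells (Homo sapiens) for cytotoxicity, read by MTT assay, with a stated time of 4 days (on this read-out lower numbers stand for higher toxicity in this test and higher numbers for lower toxicity in this test), compound 1 gives > 100000 nM, a limit of the assay.
Compound 2, `Cc1cc(C)cc(Cn2c(=O)cc(N)n(CC#N)c2=O)c1`: in this assay compound 2 gives > 100000 nM, likewise a limit.
Compound 3, `Cc1cc(C)cc(Cn2c(=O)cc(N)n(Cc3ccncc3)c2=O)c1`: in this assay compound 3 gives > 100000 nM, again a limit.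

Compound 3 therefore stands where every value shown stands, at the limit of > 100000 nM in this assay, at which 3 of the 3 values shown sit. Going by the values given here, the one step between measured neighbours, a step that the two limits leave unreadable from compound 2 to compound 3, cannot be read because both ends are limits, so no measured step bears on the change to compound 4, `Cc1cc(C)cc(Cn2c(=O)cc(N)n(Cc3ccccn3)c2=O)c1`, which is pyridin-2-yl in place of pyridin-4-yl on a saturated chain carbon bound to an aromatic nitrogen. With nothing in this assay moving off the limit, compound 4 is expected to sit there as well, a step that the limit leaves unreadable from compound 3 to compound 4 that is none beyond the scatter. Compound 4 is estimated at 200000 nM, between 80000 nM and 600000 nM.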

Compound 4, half-maximal cytotoxic concentration: > 100000 nM
Compound 4 was reported as a limit (the forecaster's own chance of this, stated with the estimate: 85%); the middle value does not contradict the limit.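

No new step can be read from compound 1, compound 2 or compound 3 to compound 4, since both ends of each step are limits: the limit of > 100000 nM in this assay, at which 4 of the 4 values shown sit.

The compounds shown leave open the size of these steps in this assay and whether any change to the shared core would give a value off the limit.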